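From a Methylbenzyl Ester to a Pyridylmethyl Ester

The compounds below may be only part of what the source reports. "The series", "measured", "known", "first", "only" and "open" are said of these compounds alone.

Compound 2 `COc1ccc(-c2csc(N)c2C(=O)OCc2ccccc2C)cc1OC` stands highest of the two compounds measured in an assay on isolated protein for inhibition of protein kinase C zeta type (Homo sapiens), with stated times of 1 h and 2.5 min, tested at 30 uM (a higher number here means more inhibition at the concentration tested (going by the name of the read-out), a lower number less inhibition), where compound 2 gives 64%. Its nearest neighbour, compound 1 `COc1ccc(-c2csc(N)c2C(=O)Oc2ccccc2)cc1OC`, gives 48%, and the step of a number 16 percentage points higher from compound 1 to compound 2 (beyond the scatter) shows that an exchange on an oxygen next to a carbonyl group moved the read-out modestly. Compound 3 `COc1ccc(-c2csc(N)c2C(=O)OCc2ccncc2)cc1OC` differs from compound 2 by pyridin-4-yl in place of 2-methylphenyl on a saturated chain carbon bound to an oxygen next to a carbonyl group. Within the data shown here, only that one measured step bears on this change, and it concerns a different exchange at the same place, so no firm direction follows. The expected step is a number 12 percentage points lower from compound 2 to compound 3 (beyond the scatter). Compound 3 is estimated at 52%, within 32% to 72%.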

Compound 3, a percentage reported as inhibition, at one concentration (the size of the read-out at that concentration, not a potency): 53%
Estimate against measurement, compound 3: 1 percentage points below; the range from low to high includes it.
By their numbers in this assay, from the lowest: compounds 1 and 3 (each within the scatter of the next); then compound 2.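

Pyridin-4-yl in place of 2-methylphenyl on the saturated chain carbon gives a number 11 percentage points lower from compound 2 to compound 3 (beyond the scatter) in this assay, so the gain seen with 2-methylbenzyl does not carry over to (pyridin-4-yl)methyl. Set against phenyl, (pyridin-4-yl)methyl gives a number 5 percentage points higher from compound 1 to compound 3 (within the scatter), which leaves the two groups indistinguishable in this read-out. No measurement shown accounts for the drop from compound 2 to compound 3.

As far as these compounds go, the step swaps the methyl-bearing carbon ring for a ring with nitrogen, so it remains open which of these differences matters. A plain benzyl group, or pyridin-3-yl at the same place, would help to separate them.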